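A few compounds are considered here, and "the series" means these few. Any claim that something is new, unique, unknown or untested is made for them only; others in the source may bear on it.

Values in an assay on isolated protein for inhibition of retinal dehydrogenase 2 (Homo sapiens); a higher number here means a weaker inhibitor, a lower number a stronger inhibitor:
compound 1 `Cn1ncc2c(=O)n(-c3ccccc3)c(SC(C)(C)c3ccccc3)nc21`: 2200 nM
compound 2 `COc1cccc(C(C)Sc2nc3c(cnn3C)c(=O)n2-c2ccccc2)c1`: 108 nM
compound 3 `COc1ccccc1C(C)Sc1nc2c(cnn2C)c(=O)n1-c1ccccc1`: 136 nM

Compound 3 holds the second highest of the three numbers. Its nearest neighbour is compound 2, and the step of a 1.3-fold higher number from compound 2 to compound 3 (0.10 log units; within the scatter) lies within the scatter, so the two are not separated. Within the data shown here, compound 1 gives a higher number than compound 3, beyond the scatter, but the two differ in more than one place and no single step joins them.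

Compound 4 `CC(Sc1nc2c(cnn2C)c(=O)n1-c1ccccc1)c1cncnc1` is not yet measured. Relative to compound 3 the change is pyrimidin-5-yl in place of 2-methoxyphenyl on a saturated chain carbon bound to a saturated chain carbon and a sulfur. Among the measured compounds shown here, the only single step at this position, a 1.3-fold higher number from compound 2 to compound 3 (0.10 log units; within the scatter), moves the methoxy on a carbon-only ring and is within the scatter; no measured step exchanges the carbon-only ring for a ring with hetero atoms. The expectation therefore rests on little evidence. For compound 4 a modest step toward a higher number is expected, a 2.2-fold higher number from compound 3 to compound 4 (0.34 log units; beyond the scatter), with a wide margin either way. The estimate for compound 4 in this assay is 300 nM, within a range from 100 nM to 1200 nM.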

Compound 4, half-maximal inhibitory concentration: 380 nM
Estimate against measurement, compound 4: 1.3-fold (0.10 log units) below, and the stated range covers the measured number.
By their numbers in this assay, from the lowest: compounds 2 and 3 (each within the scatter of the next); then compound 4; then compound 1.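

In this assay this position responds to a change of ring where moving the methoxy did not: pyrimidin-5-yl in place of 2-methoxyphenyl gives a 2.8-fold higher number from compound 3 to compound 4 (0.45 log units; beyond the scatter) and, in place of 3-methoxyphenyl, a 3.5-fold higher number from compound 2 to compound 4 (0.55 log units; beyond the scatter) beyond the scatter, whereas a 1.3-fold higher number from compound 2 to compound 3 (0.10 log units; within the scatter) separated nothing. A ring with hetero atoms on this chain carbon is therefore compatible with a modest loss only, and the exchange of 1-methyl-1-phenylethyl on the sulfur for 1-(pyrimidin-5-yl)ethyl still gives a 5.8-fold lower number from compound 1 to compound 4 (0.76 log units; beyond the scatter) in the opposite direction. Nothing at hand gives a reason for these steps.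

The pyrimidin-5-yl exchange removes the methoxy and brings in ring nitrogens at once, so the two contributions stay unseparated. A plain phenyl or a pyridyl on the same chain carbon would divide them, and an amine on the ring remains an open question here.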